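A 4-Bromophenyl Gives Way to Acetamido

A few compounds are considered here, and "the series" means these few. Any claim that something is new, unique, unknown or untested is made for them only; others in the source may bear on it.

Compound 1 `O=C1Nc2ccc(S(=O)(=O)N3CCOCC3)cc2/C1=N/c1ccc(Br)cc1`: 44800 nM
Compound 2 `Cc1ccc(S(=O)(=O)N/N=C2\C(=O)Nc3ccc(S(=O)(=O)N4CCOCC4)cc32)cc1`: 38400 nM

Both compounds were read in a functional assay on MCF7 cells (Homo sapiens) for cytotoxicity, read by sulforhodamine B assay, with a stated time of 24 h (on this read-out higher numbers stand for weaker inhibition and lower numbers for stronger inhibition), and compound 1 lies within the scatter of compound 2, so neither stands apart. The next step leads to compound 3 `CC(=O)N/N=C1\C(=O)Nc2ccc(S(=O)(=O)N3CCOCC3)cc21`, with acetamido in place of 4-bromophenyl on a double-bonded nitrogen. Going by the values given here, no measured step shows what this change does. Compound 2 also lacks the 4-bromophenyl, and compound 2 gives 38400 nM, so no step beyond the scatter is expected in this assay. The estimate is a 1.1-fold lower number from compound 1 to compound 3 (0.05 log units; within the scatter), with no firm direction expected. For compound 3 the expected value is 40000 nM, with an estimated range from 15000 nM to 100000 nM.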

Compound 3, half-maximal inhibitory concentration: 56000 nM
Compound 3: the middle estimate sits 1.4-fold (0.15 log units) below what was measured; low and high end bracket the measured number.
By their numbers in this assay, from the lowest: compounds 2, 1 and 3 (each within the scatter of the next).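

In this assay acetamido in place of 4-bromophenyl on a double-bonded nitrogen gives a 1.3-fold higher number from compound 1 to compound 3 (0.10 log units; within the scatter) and acetyl in place of (4-methylphenyl)sulfonyl on an amine nitrogen gives a 1.5-fold higher number from compound 2 to compound 3 (0.16 log units; within the scatter) and both steps lie within the scatter. At this position, then, groups with and without a six-membered aromatic ring give readings that cannot be told apart, so neither change shifts the number measurably. Nothing measured here offers an explanation for this result. Still open, from the compounds shown here alone, is whether an amine or a carboxylic acid at this position would give a step beyond the scatter.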